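A few compounds are considered here, and "the series" means these few. Any claim that something is new, unique, unknown or untested is made for them only; others in the source may bear on it.

Compound 2, with the structure `CC1CCC(NC(=O)c2cc3c(F)cc(F)cc3[nH]2)CC1`, is measured in a physicochemical assay for solubility, measured as thermodynamic solubility, with a stated time of 24 h, at pH 6.8 (a higher number here means a more soluble compound, a lower number a less soluble compound), and what it gives there is a limit of the assay rather than a number: compound 2 gives < 4000 nM. Going by the values given here, the only other measured compound, compound 1 (`C[C@H]1CCCC[C@H]1NC(=O)c1cc2c(F)cc(F)cc2[nH]1`), sits at the same limit in this assay, where compound 1 gives < 4000 nM. Among the compounds with values here, the one measured step, a step that the two limits leave unreadable from compound 1 to compound 2, is therefore unreadable, and the limit of < 4000 nM in this assay, at which 2 of the 2 values shown sit, tells only that both measured compounds fall at that limit. Compound 3 (`C[C@H]1CC[C@H](NC(=O)c2cc3c(F)cc(F)cc3[nH]2)CC1`) is the compound still to be measured. The change from compound 2 to compound 3 is the two compounds have the same atoms and bonds; at least one stereo element is drawn with a configuration in one of them and without one in the other: 2 of 2 stereo elements differ; a stereocentre at a saturated ring carbon is drawn without a configuration in compound 2 and r in compound 3; a stereocentre at a saturated ring carbon is drawn without a configuration in compound 2 and r in compound 3; no atom leaves and none enters, so the two compounds differ only in whether the stereocentres are drawn with a configuration. Within the data shown here, no measured step bears on such a change, and the one step that exists could not be read. The step from compound 2 to compound 3 is therefore expected to be none beyond the scatter in this assay, so the estimate is a step that the limit leaves unreadable from compound 2 to compound 3. Compound 3 is expected to give 2000 nM, in a range from 500 nM to 4000 nM, most likely again reported only as a limit.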

Compound 3, solubility: < 4000 nM
Compound 3 gave a limit, no number; the forecaster's own chance of this, stated with the estimate: 90%; the middle value lies beyond the limit too.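

No step can be read from compound 3 to compound 1 or compound 2 in this assay, because each of the three compounds gives a limit of the assay rather than a number: the limit of < 4000 nM in this assay, at which 3 of the 3 values shown sit.

The compounds shown leave open how soluble each one actually is, and whether the configuration drawn in compound 3 matters at all.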